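Adding a Fluoro Group to Compound 2

The source may report more compounds than this note shows. Statements on the series, on what has been measured and on what is new or still open speak of the compounds shown alone.

Of the compounds shown here, two have been measured in a functional assay on the whole organism (aorta) with Rattus norvegicus as the target; a higher number here means a larger maximal response, a lower number a smaller maximal response. Compound 1 `O=C1C(Nc2ccc(F)cc2F)=CC(=O)c2ncccc21` gives 94% in this assay. Compound 2 `O=C1C=C(Nc2ccc(F)cc2)C(=O)c2cnccc21` gives 72% in this assay, the lower of the two numbers, and its gap to compound 1 lies beyond the usual scatter. These two compounds differ in more than one place, so that gap cannot be tied to a single change. Compound 3 `O=C1C=C(Nc2ccc(F)c(F)c2)C(=O)c2cnccc21` has not yet been measured. It differs from compound 2 in one place: fluoro in place of hydrogen on an aromatic carbon. Among the compounds with values here, no measured pair shows a step of this kind, so the expected change in this assay is small, possibly none beyond the scatter, and its direction is uncertain. Compound 3 is expected to give about 75% in this assay, within a range from 55% to 95%. This estimate means an expected step of a number 3 percentage points higher from compound 2 to compound 3 (within the scatter).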

Compound 3, largest response reached (Emax), in percent of the reference or control that the assay uses: 81%
Estimate against measurement, compound 3: 6 percentage points below, and the stated range covers the measured number.
By their numbers in this assay, from the lowest: compounds 2 and 3 (each within the scatter of the next); then compound 1.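

In this assay, putting fluoro in place of hydrogen on this aromatic carbon, ortho to a fluoro group and meta to a large group, gives a number 9 percentage points higher from compound 2 to compound 3 (within the scatter). Within the data shown here, this is the only single-place step in the set, and it shows that a fluoro group can sit at this position without a change that can be told apart from the usual scatter, so compound 2 and compound 3 count as equal here. Among these compounds, nothing measured so far offers an explanation for this result.

On these data alone, a single small atom says little about the position as a whole, so it remains open whether a bigger or different group there, such as a methoxy group, an amine or a carboxylic acid, would leave the maximal response just as it is. As far as these compounds go, it is also open whether the same fluoro step would give a similar result on the core of compound 1.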